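This account rests on a few compounds, and the source may have more. Where it says the series, first, only, none or still open, it means among the compounds named here.

Working notes on the series. In a functional assay on HeLa cells (Homo sapiens) for antiproliferative activity, read by MTT assay, with a stated time of 24 h (a higher number here means a weaker inhibitor, a lower number a stronger inhibitor), compound 2 (`COc1ccc(S(=O)(=O)n2c(-c3cn(-c4ccccc4)nc3-c3ccc(F)cc3)nc3ccccc32)cc1`) gives 390 nM, and compound 1 (`Cc1ccc(-c2nn(-c3ccccc3)cc2-c2nc3ccccc3n2S(=O)(=O)c2ccc(Br)cc2)cc1`) gives 2340 nM. Among the measured compounds shown here, compound 2 therefore holds the lower of the two numbers so far, and its gap to compound 1 lies beyond the scatter.

Compound 3 (`O=S(=O)(c1ccc(Cl)cc1)n1c(-c2cn(-c3ccccc3)nc2-c2ccc(F)cc2)nc2ccccc21`) departs from compound 2 in one place, with chloro in place of methoxy on an aromatic carbon, para to a large group: chloro in place of methoxy on an aromatic carbon. The same difference reads as 4-methoxyphenyl to 4-chlorophenyl.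

For the measured compounds named here, no measured pair differs in one place only, so the size of this step has no direct precedent, and the uncertainty is wide. Going by the values given here, with only two numbers available, the sole guide to direction is that compound 1, at 2340 nM, sits higher. A modest rise in this assay is therefore expected, of about the size of the scatter or slightly beyond it, and the estimated step is a 2.1-fold higher number from compound 2 to compound 3 (0.31 log units; beyond the scatter). For compound 3 the expected value is 800 nM, with an estimated range of 250 nM to 2500 nM.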

Compound 3, half-maximal inhibitory concentration: 3450 nM
The estimate for compound 3 lay 4.3-fold (0.63 log units) below the measured number; measured number outside the range, above it.
By their numbers in this assay, from the lowest: compound 2; then compounds 1 and 3 (each within the scatter of the next).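

In this assay, among the compounds shown here, the change from (4-methoxyphenyl)sulfonyl to (4-chlorophenyl)sulfonyl gives an 8.8-fold higher number from compound 2 to compound 3 (0.95 log units; beyond the scatter) and so provides the first reading of a difference at one place, with the rest of the structure held constant. This aromatic carbon, para to a large group, is therefore not indifferent to its substituent: the number moves beyond the scatter, and of the two groups compared here, methoxy gives the lower number. No measurement in hand bears on why the step has this size.

As far as these compounds go, how a hydrogen, a hydroxyl or an amine at this carbon would compare remains open, as does whether the rise reflects the departure of methoxy or the arrival of chloro. A single step also leaves open whether the same change would give a similar difference where the rest of the molecule differs, as it does in compound 1, which carries a bromo group on its sulfonyl-bound ring.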